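Cyano Gives Way to Carboxy in Compound 4

The source may report more compounds than this note shows. Statements on the series, on what has been measured and on what is new or still open speak of the compounds shown alone.

In a functional assay on MV4-11 cells (Homo sapiens) for antiproliferative activity, read by MTT assay (a lower number here means a stronger inhibitor of growth, a higher number a weaker inhibitor of growth), compound 1 `CCCNc1nc(Nc2ccc(OC)cc2)nc2ccccc12` gives 5880 nM while compound 2 `COc1ccc(N(C)c2nc(NCCCO)c3ccccc3n2)cc1` gives 70100 nM in the same test. The result for compound 3 `N#Cc1ccc(Nc2nc(NC3CCCC3)c3ccccc3n2)cc1` stands as "not determined" (no result reported) and so offers no number to start from. The change to compound 4 `O=C(O)c1ccc(Nc2nc(NC3CCCC3)c3ccccc3n2)cc1` is carboxy in place of cyano on an aromatic carbon para to a large group. For the measured compounds named here, no measured step speaks to this change, so neither a size nor a direction of step can be expected in this assay from compound 3. The values of compound 1 at 5880 nM and compound 2 at 70100 nM are all that an expectation can lean on. Within this assay compound 4 is expected near 20000 nM with an estimated range of 4000 nM to 90000 nM on present evidence.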

Compound 4, concentration for 50% growth inhibition: 7500 nM
Compound 4: middle estimate off by 2.7-fold (0.43 log units), on the high side; low and high end bracket the measured number.
By their numbers in this assay, from the lowest: compounds 1 and 4 (each within the scatter of the next); then compound 2.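

For the compounds shown here, compound 3 offers no number to compare in this assay, so no step to compound 4 (at 7500 nM) can be read. On these data alone, the effect of carboxy in place of cyano on growth inhibition therefore stays open. Nothing available accounts for the value of compound 4.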